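Pyrimidin-2-yl in place of 1,3-oxazol-2-yl: working notes

The source may report more compounds than this note shows. Statements on the series, on what has been measured and on what is new or still open speak of the compounds shown alone.

In an ADME assay on the whole organism (Mus musculus, strain ICR) for pharmacokinetics, at a dose of 50 mg/kg by the oral route (a higher number here means more compound in the circulation at the dose given, a lower number less compound in the circulation), compound 2 `O=C1CC(c2ncco2)CN1c1cnn2c1CN(C(=O)Nc1cc(F)c(F)c(F)c1)C(C1CC1)C2` gives 18000 nM, and compound 1 `O=C1CC(Oc2ncccn2)CN1c1cnn2c1CN(C(=O)Nc1cc(F)c(F)c(F)c1)C(C1CC1)C2` gives 10300 nM. Among the compounds with values here, these are the only two numbers available so far, and they lie within the scatter of each other, so compound 2 is not clearly separated from compound 1.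

Compound 3 `O=C1CC(c2ncccn2)CN1c1cnn2c1CN(C(=O)Nc1cc(F)c(F)c(F)c1)C(C1CC1)C2` has not yet been measured. Its change from compound 2 is pyrimidin-2-yl in place of 1,3-oxazol-2-yl on a saturated ring carbon, two ring bonds from the ring nitrogen.

Within the data shown here, one measured step bears on this change. On the same ring carbon, 1,3-oxazol-2-yl in place of (pyrimidin-2-yl)oxy gave a 1.7-fold higher number from compound 1 to compound 2 (0.24 log units; within the scatter). This is a single step and involves a different group, so it is only a loose guide. Among the measured compounds shown here, with a 1.7-fold higher number from compound 1 to compound 2 (0.24 log units; within the scatter) as the sole evidence, no step beyond the scatter is expected in this assay, and no firm direction can be assigned.

The estimated change is a 1.3-fold lower number from compound 2 to compound 3 (0.11 log units; within the scatter). Compound 3 is expected at 14000 nM, with an estimated range of 6500 nM to 30000 nM.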

Compound 3, maximal plasma concentration: 12000 nM
The estimate for compound 3 lay 1.2-fold (0.07 log units) above the measured number, within the range that was stated.
By their numbers in this assay, from the lowest: compounds 1, 3 and 2 (each within the scatter of the next).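

Swapping the oxazole for the larger six-membered ring on this saturated ring carbon, two ring bonds from the ring nitrogen, gives a 1.5-fold lower number from compound 2 to compound 3 (0.18 log units; within the scatter) in this assay, so the change in ring size does not separate the two compounds in this read-out. Within the data shown here, removing the oxygen link while keeping the pyrimidine gives a 1.2-fold higher number from compound 1 to compound 3 (0.07 log units; within the scatter), the first direct reading of that link, and it too stays within the scatter. All three groups at this position therefore sit within the scatter of one another, so none of them stands out here, and no measurement at hand accounts for the small differences.

The compounds shown carry only aromatic rings at this position, directly attached or through oxygen, so it remains open whether a primary amine, a carboxylic acid or a longer alkyl chain on the same ring carbon would produce a step beyond the scatter. Also open, going by these compounds, is whether these three compounds would stay this close in any read-out other than maximal plasma concentration, such as overall exposure or clearance.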